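From 2-Chlorophenyl to 2-Fluorophenyl: Expecting Compound 4

The source may hold more compounds than are shown below. What is called first, only, known or untested is meant among the compounds shown, and "the series" means these compounds.

In a functional assay on the whole organism (Hindlimb) for inhibition, with Mus musculus as the target, with a stated time of 0.5 h (on this read-out higher numbers stand for an effect only at larger amounts of compound and lower numbers for an effect already at smaller amounts), compound 1 `CC1(C)CC12NC(=O)N(NC(=O)c1ccccc1)C2=O` gives 300 mg/kg. Compound 2 `Cc1cccc(C(=O)NN2C(=O)NC3(CC3(C)C)C2=O)c1` gives 100 mg/kg in this assay, and compound 3 `CC1(C)CC12NC(=O)N(NC(=O)c1ccccc1Cl)C2=O` gives 300 mg/kg. Going by the values given here, compound 3 thus stands level with compound 1 and shares the highest number of the three; the one step beyond the scatter that touches it is a 3.0-fold higher number from compound 2 to compound 3 (0.48 log units; beyond the scatter). Compound 4 `CC1(C)CC12NC(=O)N(NC(=O)c1ccccc1F)C2=O` differs from compound 3 in a single place: fluoro in place of chloro on an aromatic carbon. The step bearing most on this swap is no change at the digits printed from compound 1 to compound 3 (within the scatter), where adding chloro left the number unchanged, whereas a 3.0-fold lower number from compound 1 to compound 2 (0.48 log units; beyond the scatter) concerned methyl rather than a halogen. Since chloro and hydrogen give the same number, no step beyond the scatter is expected, so no change at the digits printed from compound 3 to compound 4 (within the scatter) is the estimated change. Compound 4 is therefore expected at 300 mg/kg, with a range from 100 mg/kg to 1000 mg/kg.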

Compound 4, minimum effective dose: 100 mg/kg
Compound 4: the middle estimate sits 3.0-fold (0.48 log units) above what was measured, and the stated range covers the measured number.
By their numbers in this assay, from the lowest: compounds 2 and 4 (each within the scatter of the next); then compounds 1 and 3 (each within the scatter of the next).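

On the aromatic carbon ortho to a large group, the choice of halogen matters: fluoro in place of chloro gives a 3.0-fold lower number from compound 3 to compound 4 (0.48 log units; beyond the scatter), and fluoro in place of hydrogen gives a 3.0-fold lower number from compound 1 to compound 4 (0.48 log units; beyond the scatter), so the position is not as indifferent as chloro alone suggested. The 2-fluorophenyl group also matches the 3-methylphenyl group, with no change at the digits printed from compound 2 to compound 4 (within the scatter). Nothing available explains why fluoro and chloro differ here. As far as these compounds go, whether a methoxy group or an amine at this position would give a lower number remains open.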